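Pyridin-3-yl in Place of 1,3-Oxazol-5-yl: Expected Efficacy

The source may hold more compounds than are shown below. What is called first, only, known or untested is meant among the compounds shown, and "the series" means these compounds.

Measured so far, in a functional assay (Sus scrofa) with sulfonylurea receptors; K-ATP channels (Homo sapiens) as the target; on this read-out higher numbers stand for larger maximal responses and lower numbers for smaller maximal responses:
compound 1, `CC(C)=CC(=O)Nc1c(C(O)(C(F)(F)F)C(F)(F)F)ccc2ccccc12`, gives 96%
compound 2, `O=C(Nc1c(C(O)(C(F)(F)F)C(F)(F)F)ccc2ccccc12)c1cnco1`, gives 97%

Both compounds share the same core and differ only in the group attached to the carbonyl carbon of the amide. Among the two numbers, compound 2 is at the top, yet the step of a number 1 percentage points higher from compound 1 to compound 2 (within the scatter) lies within the scatter, so on this assay the two compounds cannot be told apart: both reach a maximal response close to the reference.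

Compound 3, `O=C(Nc1c(C(O)(C(F)(F)F)C(F)(F)F)ccc2ccccc12)c1cccnc1`, is not yet measured. Its difference from compound 2 is pyridin-3-yl in place of 1,3-oxazol-5-yl on a carbonyl carbon. Within the data shown here, the one measured step that bears on this change is the earlier exchange at the same carbonyl carbon, a number 1 percentage points higher from compound 1 to compound 2 (within the scatter), which replaced an open-chain group by a five-membered aromatic ring without moving the response beyond the scatter. Nothing in the data points to a change of efficacy at this position, so for compound 3 the expected step of a number 2 percentage points lower from compound 2 to compound 3 (within the scatter) is none beyond the scatter. The estimate for compound 3 in this assay is 95%, with a range from 85% to 104%.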

Compound 3, largest response reached (reported as efficacy), in percent of the reference or control that the assay uses: 97%
Estimate against measurement, compound 3: 2 percentage points below; the range from low to high includes it.
By their numbers in this assay, from the lowest: compounds 1, 2 and 3 (each within the scatter of the next).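

In this assay, exchanging the five-membered 1,3-oxazol-5-yl ring, which has 2 hetero atoms, for the six-membered pyridin-3-yl ring, which has 1, gives no change at the digits printed from compound 2 to compound 3 (within the scatter) on a carbonyl carbon whose other neighbour is an amide-type nitrogen. Set against the open-chain 2-methylprop-1-en-1-yl group, the same pyridin-3-yl ring gives a number 1 percentage points higher from compound 1 to compound 3 (within the scatter) in this comparison, so an open chain, a five-membered aromatic ring and a six-membered aromatic ring at this one place cannot be told apart by their largest response, whereas the earlier pair covered only the first two of these. The data shown offer no explanation for this lack of a detectable difference.

Going by these compounds, what remains open is whether any group at this carbonyl carbon can move the largest response beyond the scatter, for instance a carboxylic acid, an amine or a longer saturated chain in place of these three groups. These numbers also describe only how large the response becomes, and they leave open what concentration of each compound is needed to reach it.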